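The source may report more compounds than this note shows. Statements on the series, on what has been measured and on what is new or still open speak of the compounds shown alone.

In a functional assay on the whole organism (strain Wistar) with Rattus norvegicus as the target, with a stated time of 5 min (on this read-out lower numbers stand for an effect already at smaller amounts and higher numbers for an effect only at larger amounts of compound), the three measured compounds stand as follows:

compound 1 `CCC1(CCCCN2CCN(c3ccc(Cl)c(Cl)c3)CC2)C(=O)Nc2ccccc21`: > 20 mg/kg, a limit of this assay.
compound 2 `CCC1(CCCCN2CCN(c3ccc(C)c(Cl)c3)CC2)C(=O)Nc2ccccc21`: > 20 mg/kg, also a limit.
compound 3 `CCC1(CCCCN2CCN(c3ccc(OC)cc3)CC2)C(=O)Nc2ccccc21`: > 20 mg/kg, again a limit.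

Compound 3 therefore stands at a limit and not at a number, and the other two values shown are limits as well, so it cannot be placed above or below them. The step that the two limits leave unreadable from compound 1 to compound 3 and the step that the two limits leave unreadable from compound 2 to compound 3, both exchanging the aryl group on the ring nitrogen, stay unreadable, and a step that the two limits leave unreadable from compound 1 to compound 2 is unreadable for the same reason: all three values rest at the limit of > 20 mg/kg in this assay, at which 3 of the 3 values shown sit.

Compound 4 `CCC1(CCCCN2CCN(c3ccccc3Cl)CC2)C(=O)Nc2ccccc21` differs from compound 3 as follows: 2-chlorophenyl in place of 4-methoxyphenyl on an amine nitrogen in a ring. The measured aryl exchanges bear on this change only in that none produced a reading below the limit. He therefore expects no step beyond the scatter in this assay, and an estimated step that the limit leaves unreadable from compound 3 to compound 4 is what that expectation means. Compound 4 is expected at about 30 mg/kg, within 15 mg/kg to 60 mg/kg, most likely reported once more as a limit.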

Compound 4, minimum effective dose: > 20 mg/kg
Compound 4: a limit, no number; the forecaster's own chance of this, stated with the estimate: 80%; the middle value lies beyond the limit too.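

In this assay compound 4 also stands at a limit, so no step linking it to compound 1, compound 2 or compound 3 can be read: the limit of > 20 mg/kg in this assay, at which 4 of the 4 values shown sit.

The compounds shown leave open whether any of these aryl groups on the ring nitrogen gives an effect at a readable dose.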